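The compounds below may be only part of what the source reports. "The series", "measured", "known", "first", "only" and "open" are said of these compounds alone.

Measured compounds:
- compound 1 `CC(/C=N/Nc1ccc([N+](=O)[O-])cc1)=N\NC(=O)c1ccccc1` — > 100000 nM
- compound 2 `CC(/C=N/Nc1ccc([N+](=O)[O-])cc1)=N\NC(=O)c1ccccc1F` — > 100000 nM

In an ADME assay on J774 cells (Mus musculus, strain BALB/c) for cytotoxicity, read by resazurin assay, with a stated time of 72 h (on this read-out higher numbers stand for lower toxicity in this test and lower numbers for higher toxicity in this test), compound 1 gives > 100000 nM, which is a limit of the test rather than a measured number. Compound 2 gives > 100000 nM in this assay, again a limit and not a number. The step that the two limits leave unreadable from compound 1 to compound 2 therefore cannot be read. Within the data shown here, compound 2 thus stands only at a limit, and the limit of > 100000 nM in this assay, at which 2 of the 2 values shown sit, shows that the one other value sits there as well.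

Compound 3 `CC(/C=N/Nc1ccc([N+](=O)[O-])cc1)=N\NC(=O)c1ccccc1C` has not yet been tested in this assay. It differs from compound 2 by methyl in place of fluoro on an aromatic carbon. Among the measured compounds shown here, the only measured step, a step that the two limits leave unreadable from compound 1 to compound 2, offers no size to lean on, so no direction can be drawn from it. Both measured compounds sit at the limit, and compound 3 is expected to do the same. The expected step that the limit leaves unreadable from compound 2 to compound 3 would then stay within the scatter. Compound 3 is therefore estimated at 150000 nM, with a range from 50000 nM to 500000 nM.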

Compound 3, half-maximal cytotoxic concentration: > 100000 nM
Compound 3: only a limit was reported (the forecaster's own chance of this, stated with the estimate: 80%); the middle value does not contradict the limit.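

Compound 3 also stands at a limit rather than a number in this assay, so the steps linking compound 1, compound 2 and compound 3 cannot be read: the limit of > 100000 nM in this assay, at which 3 of the 3 values shown sit. The compounds shown leave open how hydrogen, fluoro and methyl on this aromatic ring compare, and at what concentration, if any, each compound harms these cells.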